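Chain methylation and Caco-2 permeability: working notes

This account rests on a few compounds, and the source may have more. Where it says the series, first, only, none or still open, it means among the compounds named here.

Of the compounds shown here, three on a shared core have been measured. Compound 1 `CCCC[C@@H](O)C(=O)N1N=CC[C@H]1C(=O)NCc1cc(Cl)ccc1-n1cnnn1` gives 9.8 10^-6 cm/s in an ADME assay on Caco-2 cells (Homo sapiens) for permeability, read by LC-MS, in the apical to basolateral direction, with a stated time of 60 min, at pH 6.5 (on this read-out lower numbers stand for lower permeability and higher numbers for higher permeability), and stands at the low end of the three numbers. Compound 3 `O=C(NCc1cc(Cl)ccc1-n1cnnn1)[C@@H]1C[C@@H]2C[C@@H]2N1C(=O)[C@H](O)c1ccccc1F` gives 16 10^-6 cm/s in this assay; its gap to compound 1 is within the scatter, so no order between the two is claimed. Compound 2 `CC(C)(C)C[C@@H](O)C(=O)N1OCC[C@H]1C(=O)NCc1cc(Cl)ccc1-n1cnnn1` gives 25 10^-6 cm/s in this assay, a gap from compound 1 that is beyond the scatter. Compound 4 `CC(C)CC[C@@H](O)C(=O)N1N=CC[C@H]1C(=O)NCc1cc(Cl)ccc1-n1cnnn1` is not yet measured and differs from compound 1 by methyl in place of hydrogen on a saturated chain carbon bound to two saturated chain carbons. Among the compounds with values here, no measured pair isolates this change, so the step is read from the change alone: a small upward step in this assay is expected, or none beyond the scatter. Compound 4 is expected to give 13 10^-6 cm/s, with a range of 7 10^-6 cm/s to 24 10^-6 cm/s. The expected step is a 1.3-fold higher number from compound 1 to compound 4 (0.12 log units; within the scatter).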

Compound 4, apparent permeability: 29 10^-6 cm/s
Compound 4: middle estimate off by 2.2-fold (0.35 log units), on the low side; measured number above the stated range.
By their numbers in this assay, from the lowest: compounds 1, 3, 2 and 4 (each within the scatter of the next, the first and the last beyond it).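

Butyl to isopentyl gives the first step that isolates a single change on this chain: in this assay, methyl in place of hydrogen on a saturated chain carbon bound to two saturated chain carbons gives a 3.0-fold higher number from compound 1 to compound 4 (0.47 log units; beyond the scatter). One added carbon at this place is therefore enough to move the number past the usual scatter. No measurement here bears on the reason for this step.

This single step does not show whether the rise carries over to the other chains on the shared core. As far as these compounds go, whether an amine or a longer chain at this place moves the number the same way also remains open.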